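Changing the aryl on the carbonyl of a sulfonamide anilide

This account rests on a few compounds, and the source may have more. Where it says the series, first, only, none or still open, it means among the compounds named here.

Compound 1 `O=C(Nc1ccc(S(=O)(=O)Nc2ccccc2Cl)cc1)c1ccc(Cl)cc1Cl`: 1260 nM
Compound 2 `O=C(NS(=O)(=O)c1ccc(NC(=O)c2ccc(Cl)cc2Cl)cc1)c1ccccc1`: > 100000 nM
Compound 3 `Cc1cc(Br)ccc1C(=O)Nc1ccc(S(=O)(=O)Nc2ccccc2)cc1`: 851 nM

In a functional assay on HEK293 cells for agonist activity at probable G-protein coupled receptor 27 (Homo sapiens), read by a luciferase reporter and beta-arrestin recruitment, with a stated time of 10 min (a higher number here means that more compound is needed for the effect, a lower number that less compound is needed), compound 3 gives the lowest of the two numbers, and compound 1 sits within the scatter of it, so no order between the two can be read. For compound 2 the assay reports only a limit, (the limit of > 100000 nM in this assay, at which 1 of the 3 values shown sits).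

Compound 4 `O=C(Nc1ccc(S(=O)(=O)Nc2ccccc2)cc1)c1cc(F)c(Cl)cc1F` differs from compound 3 by 4-chloro-2,5-difluorophenyl in place of 4-bromo-2-methylphenyl on a carbonyl carbon. For the measured compounds named here, the one measured step, an at least 79-fold higher number from compound 1 to compound 2 (1.89 log units; beyond the scatter), sits on the sulfonamide nitrogen rather than on the carbonyl carbon, so it does not bear on this change. Compounds 1 and 3 differ in two places at once, and their two values show only that they lie close together. Going by the values given here, with no step at the carbonyl to go by, compound 4 is expected to stay near compound 3, a 1.1-fold higher number from compound 3 to compound 4 (0.02 log units; within the scatter). The estimate for compound 4 is 900 nM, between 300 nM and 3000 nM.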

Compound 4, half-maximal effective concentration: 141 nM
Compound 4: the middle estimate sits 6.4-fold (0.81 log units) above what was measured, outside the stated range (below it).
By their numbers in this assay, from the lowest: compound 4; then compounds 3 and 1 (each within the scatter of the next). At a limit, above all of these: compound 2.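

In this assay the aryl group on the carbonyl carbon can move the number on its own: 4-chloro-2,5-difluorophenyl in place of 4-bromo-2-methylphenyl gives a 6.0-fold lower number from compound 3 to compound 4 (0.78 log units; beyond the scatter) on an otherwise unchanged core. This is the only single change shown at this position, since the earlier step lay on the sulfonamide nitrogen. Nothing measured here says what lies behind the change. The compounds shown leave open whether the chlorine, the fluorines or the loss of the methyl carries the step, and how an amine or a carboxylic acid on this aryl ring would read.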